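Ester variation on a triterpenoid core: a nitrofuran ester

The compounds below may be only part of what the source reports. "The series", "measured", "known", "first", "only" and "open" are said of these compounds alone.

Measured compounds:
compound 1, `CC(=O)O[C@H]1CC[C@]2(C)[C@H](CC[C@@](C)(O)[C@H]2CC[C@@H]2C(C)=CC[C@H]3[C@H](CC[C@]3(C)O)C2(C)C)OC1(C)C`: 38000 nM
compound 2, `CC1=CC[C@H]2[C@H](CC[C@]2(C)O)C(C)(C)[C@@H]1CC[C@H]1[C@]2(C)CC[C@H](OC(=O)NS(=O)(=O)c3ccc(C)cc3)C(C)(C)O[C@H]2CC[C@@]1(C)O`: 47100 nM
compound 3, `CC1=CC[C@H]2[C@H](CC[C@]2(C)O)C(C)(C)[C@@H]1CC[C@H]1[C@]2(C)CC[C@H](OC(=O)c3ccc(C(F)(F)F)c(F)c3)C(C)(C)O[C@H]2CC[C@@]1(C)O`: 22200 nM

The three measured compounds share one core and differ only in the group attached to the carbonyl carbon of the ester. In a functional assay on MDA-MB-231 cells (Homo sapiens) for antiproliferative activity, read by MTT assay, with a stated time of 72 h (on this read-out lower numbers stand for stronger inhibition and higher numbers for weaker inhibition), compound 1 gives 38000 nM, the second highest of the three numbers. Its nearest neighbour is compound 2, with a 1.2-fold higher number from compound 1 to compound 2 (0.09 log units; within the scatter); the furthest is compound 3, with a 1.7-fold lower number from compound 1 to compound 3 (0.23 log units; within the scatter). Between the two non-methyl groups, a 2.1-fold lower number from compound 2 to compound 3 (0.33 log units; beyond the scatter).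

Compound 4, `CC1=CC[C@H]2[C@H](CC[C@]2(C)O)C(C)(C)[C@@H]1CC[C@H]1[C@]2(C)CC[C@H](OC(=O)c3ccc([N+](=O)[O-])o3)C(C)(C)O[C@H]2CC[C@@]1(C)O`, has not yet been measured in this assay. Relative to compound 1 the change is 5-nitrofuran-2-yl in place of methyl on a carbonyl carbon. The steps from compound 1 to compound 2 and from compound 1 to compound 3 bear on it, as both exchange the same methyl on the carbonyl carbon, and neither left the scatter. The replacement by an aromatic ring in compound 3 gave the lowest number of the three, so a small downward step at most is expected for compound 4, with a 1.5-fold lower number from compound 1 to compound 4 (0.16 log units; within the scatter). Compound 4 is therefore estimated at 26000 nM, with a range from 11000 nM to 60000 nM.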

Compound 4, half-maximal inhibitory concentration: 11100 nM
The estimate for compound 4 lay 2.3-fold (0.37 log units) above the measured number; measured number inside the range.
By their numbers in this assay, from the lowest: compounds 4, 3, 1 and 2 (each within the scatter of the next, the first and the last beyond it).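

In this assay, among the compounds shown here, 5-nitrofuran-2-yl is the first replacement of the methyl on the carbonyl carbon to leave the scatter, with a 3.4-fold lower number from compound 1 to compound 4 (0.53 log units; beyond the scatter), whereas the exchanges in compounds 2 and 3 stayed within it. The new group also stands clearly apart from the ((4-methylphenyl)sulfonyl)amino group, with a 4.2-fold lower number from compound 2 to compound 4 (0.63 log units; beyond the scatter), but it cannot be separated from the 3-fluoro-4-(trifluoromethyl)phenyl group, with a 2.0-fold lower number from compound 3 to compound 4 (0.30 log units; within the scatter), so the result shows that this position can shift the number beyond the scatter without singling out 5-nitrofuran-2-yl as the best of the groups shown. No measurement given here accounts for the size of this step.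

The compounds shown leave open whether the step belongs to the nitro group or to the furan ring; a furan-2-yl group without the nitro group, or a 5-aminofuran-2-yl group, would separate the two. They also leave open how this position responds to a simple phenyl ring, a longer alkyl chain or a group carrying a carboxylic acid on the same carbonyl carbon.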